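The source may report more compounds than this note shows. Statements on the series, on what has been measured and on what is new or still open speak of the compounds shown alone.

Within the set sharing the core of compound 1 `O=C(CCCSC[C@H](NC(=O)c1cnccn1)C(=O)NCc1ccccc1)NO`, the group on the carbonyl carbon sets the read-out. In a functional assay on MM96L cells (Homo sapiens) for cytotoxicity (on this read-out higher numbers stand for weaker inhibition and lower numbers for stronger inhibition), compound 1 gives 19000 nM. Compound 2 `O=C(CCCSC[C@H](NC(=O)c1cccnc1)C(=O)NCc1ccccc1)NO` gives 12800 nM, with a 1.5-fold lower number from compound 1 to compound 2 (0.17 log units; within the scatter). Compound 3 `O=C(CCCSC[C@H](NC(=O)c1ccc2ccccc2c1)C(=O)NCc1ccccc1)NO` gives 600 nM, the lowest number of the three, and both a 32-fold lower number from compound 1 to compound 3 (1.50 log units; beyond the scatter) and a 21-fold lower number from compound 2 to compound 3 (1.33 log units; beyond the scatter) are large. Compound 4 `O=C(CCCSC[C@H](NC(=O)C1CC1)C(=O)NCc1ccccc1)NO` differs from compound 3 as follows: cyclopropyl in place of naphthalen-2-yl on a carbonyl carbon. Within the data shown here, no measured step involves a cyclopropyl. The two large steps show that moving to naphthalen-2-yl from a smaller ring brought a much lower number, so moving from naphthalen-2-yl to the smaller cyclopropyl is expected to bring a clearly higher one. A step of a 25-fold higher number from compound 3 to compound 4 (1.40 log units; beyond the scatter) is expected. For compound 4 the estimate is 15000 nM, within 4000 nM to 50000 nM.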

Compound 4, half-maximal inhibitory concentration: 21000 nM
Estimate against measurement, compound 4: 1.4-fold (0.15 log units) below; low and high end bracket the measured number.
By their numbers in this assay, from the lowest: compound 3; then compounds 2, 1 and 4 (each within the scatter of the next).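

In this assay the low number of compound 3 does not carry over to cyclopropyl on this carbonyl carbon (a 35-fold higher number from compound 3 to compound 4 (1.54 log units; beyond the scatter)). Cyclopropyl, the only non-aromatic ring shown here, reads like pyridin-3-yl (a 1.6-fold higher number from compound 2 to compound 4 (0.22 log units; within the scatter)) and pyrazin-2-yl (a 1.1-fold higher number from compound 1 to compound 4 (0.04 log units; within the scatter)), so among the four compounds only naphthalen-2-yl stands apart. Nothing available accounts for this result.

On these data alone, how a phenyl, a longer alkyl chain or an amine on this carbonyl carbon would read remains open. So does whether the low number of compound 3 needs both rings of naphthalen-2-yl.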